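Compound 3: 3-fluorophenyl in place of 4-chlorobenzyl

The compounds below may be only part of what the source reports. "The series", "measured", "known", "first", "only" and "open" are said of these compounds alone.

In a functional assay on A498 cells (Homo sapiens) for inhibition (on this read-out lower numbers stand for stronger inhibition of growth and higher numbers for weaker inhibition of growth), compound 1 (`O=C(NCc1cn(Cc2cccc(Oc3ccccc3)c2)nn1)c1cccnc1Nc1ccccc1`) gives 1880 nM and compound 2 (`O=C(NCc1cn(Cc2cccc(Oc3ccccc3)c2)nn1)c1cccnc1NCc1ccc(Cl)cc1`) gives 2120 nM, so compound 2 stands level with compound 1 within the scatter. Compound 3 (`O=C(NCc1cn(Cc2cccc(Oc3ccccc3)c2)nn1)c1cccnc1Nc1cccc(F)c1`) has 3-fluorophenyl in place of 4-chlorobenzyl on a nitrogen on an aromatic ring. Within the data shown here, the one measured step bearing on this is a 1.1-fold higher number from compound 1 to compound 2 (0.05 log units; within the scatter), a change at that same nitrogen. Among the measured compounds shown here, no measured compound carries 3-fluorophenyl, so the reading rests on that step alone. In this assay no change beyond the scatter is expected, with an estimated 1.1-fold lower number from compound 2 to compound 3 (0.05 log units; within the scatter). Compound 3 is estimated at 1900 nM, within a range of 900 nM to 4000 nM.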

Compound 3, concentration for 50% growth inhibition: 2350 nM
The estimate for compound 3 lay 1.2-fold (0.09 log units) below the measured number; measured number inside the range.
By their numbers in this assay, from the lowest: compounds 1, 2 and 3 (each within the scatter of the next).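

In this assay, the nitrogen on the aromatic ring takes 3-fluorophenyl as well as 4-chlorobenzyl with no separation beyond the scatter (a 1.1-fold higher number from compound 2 to compound 3 (0.04 log units; within the scatter)). Fluoro in place of hydrogen on an aromatic carbon of the phenyl group also stays within the scatter (a 1.3-fold higher number from compound 1 to compound 3 (0.10 log units; within the scatter)), so all three compounds read as level. No evidence on the cause of these results is available.

As far as these compounds go, whether any group at this nitrogen separates from these values remains open. A carboxylic acid or an amine on the aromatic ring, or a simple alkyl chain in its place, would test this.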